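Clearance outlook for compound 4 after aryl group exchange

A few compounds are considered here, and "the series" means these few. Any claim that something is new, unique, unknown or untested is made for them only; others in the source may bear on it.

Compound 3 `C#CCC(O)(c1ccc(N2CCN(S(=O)(=O)c3ccc(N)nc3)C[C@@H]2C#CC)cc1)C(F)(F)F` stands lowest of the two numbers in an ADME assay (liver) for metabolic stability, with Liver microsome (Rattus norvegicus) as the target, using microsomes and NADPH, with a stated time of 30 min (on this read-out lower numbers stand for slow clearance and higher numbers for fast clearance), giving 59 mL.min-1.g-1. Compound 2 `CC#C[C@H]1CN(S(=O)(=O)c2ccc(N)nc2)CCN1c1ccc(S(=O)(=NC)C(F)(F)F)cc1` gives 257 mL.min-1.g-1 in this assay. Compound 1 `CC#C[C@H]1CN(S(=O)(=O)c2ccc(N)nc2)CCN1c1ccccc1` reaches only a limit in this assay, > 399 mL.min-1.g-1 (the limit of > 399 mL.min-1.g-1 in this assay, at which 1 of the 3 values shown sits). The move to compound 4 `CC#C[C@H]1CN(S(=O)(=O)c2ccc(N)nc2)CCN1c1ccc(C(=O)NC)cc1` is a group of 4 heavy atoms (2 carbon, 1 nitrogen, 1 oxygen; no ring) in place of a group of 9 heavy atoms (5 carbon, 1 oxygen, 3 fluorine; no ring), on an aromatic carbon. The measured steps that bear on substitution at this aromatic carbon are an at least 6.7-fold lower number from compound 1 to compound 3 (0.83 log units; beyond the scatter), a 4.4-fold lower number from compound 2 to compound 3 (0.64 log units; beyond the scatter) and an at least 1.5-fold lower number from compound 1 to compound 2 (0.19 log units; that floor lies within the scatter): each group placed there gave a lower number, and the group present in compound 3 gave the lowest. Relative to compound 3, a smaller group enters in compound 4, and the step of a 2.5-fold higher number from compound 3 to compound 4 (0.41 log units; beyond the scatter) is expected to undo part of that gain. Compound 4 is therefore estimated at 150 mL.min-1.g-1, within 60 mL.min-1.g-1 to 390 mL.min-1.g-1.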

Compound 4, intrinsic clearance in microsomes: 41 mL.min-1.g-1
Estimate against measurement, compound 4: 3.7-fold (0.56 log units) above, outside the stated range (below it).
By their numbers in this assay, from the lowest: compounds 4 and 3 (each within the scatter of the next); then compound 2. At a limit, above all of these: compound 1.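

In this assay, methylcarbamoyl on this aromatic carbon, para to a large group, gives a result that cannot be separated from that of the larger group in compound 3: a 1.4-fold lower number from compound 3 to compound 4 (0.16 log units; within the scatter). The same exchange does separate from the group in compound 2, a 6.3-fold lower number from compound 2 to compound 4 (0.80 log units; beyond the scatter), and from hydrogen, an at least 9.7-fold lower number from compound 1 to compound 4 (0.98 log units; beyond the scatter). Compound 1 stands at a limit, so that last step is only a floor: the limit of > 399 mL.min-1.g-1 in this assay, at which 1 of the 4 values shown sits.

Open, on these data alone, is whether a carboxylic acid, an amine or a longer amide chain at this carbon would give a similar number.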